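This account rests on a few compounds, and the source may have more. Where it says the series, first, only, none or still open, it means among the compounds named here.

Of the compounds shown here, three here have been tested and one has not. Compound 1 `CCOC(=O)c1sc2ccc(NCc3nc[nH]c3C)cc2c1NC(=O)c1ccc(C)cc1` carries a 4-methylphenyl on its carbonyl carbon and a (5-methyl-1H-imidazol-4-yl)methyl on the nitrogen on the aromatic ring. In a functional assay on HeLa cells (Homo sapiens) for antiproliferative activity, read by MTT assay, with a stated time of 48 h (on this read-out lower numbers stand for stronger inhibition of growth and higher numbers for weaker inhibition of growth), compound 1 gives 11400 nM as its number. Compound 2 `CCOC(=O)c1sc2ccc(NCc3nc[nH]c3C)cc2c1NC(=O)c1ccc(F)c(Cl)c1` differs from compound 1 by one change only, (3-chloro-4-fluorophenyl in place of 4-methylphenyl on a carbonyl carbon), and in this assay compound 2 gives 2910 nM as its number, so that the step is a 3.9-fold lower number from compound 1 to compound 2 (0.59 log units; beyond the scatter). Compound 3 `CCOC(=O)c1sc2ccc(N)cc2c1NC(=O)c1ccc(C)cc1` keeps the 4-methylphenyl of compound 1 but carries a bare nitrogen on the aromatic ring, and in this assay compound 3 gives 24400 nM as its number, a step of a 2.1-fold higher number from compound 1 to compound 3 (0.33 log units; beyond the scatter), which leaves compound 3 with the highest number of the three.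

Compound 4 `CCOC(=O)c1sc2ccc(N)cc2c1NC(=O)c1ccc(F)c(Cl)c1` awaits its measurement. It differs from compound 3 by 3-chloro-4-fluorophenyl in place of 4-methylphenyl on a carbonyl carbon, the same change that turned compound 1 into compound 2, at a place described in the same words. The two cores on which this change is made differ from each other by hydrogen in place of (5-methyl-1H-imidazol-4-yl)methyl on a nitrogen on an aromatic ring. Because the change from compound 1 to compound 2 gave a 3.9-fold lower number from compound 1 to compound 2 (0.59 log units; beyond the scatter), a step of similar size is expected from compound 3 to compound 4, namely a 3.8-fold lower number from compound 3 to compound 4 (0.57 log units; beyond the scatter). For compound 4 the expected number in this assay is therefore 6500 nM, estimated to fall between 3000 nM and 14000 nM.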

Compound 4, concentration for 50% growth inhibition: 12300 nM
Compound 4: the middle estimate sits 1.9-fold (0.28 log units) below what was measured, and the stated range covers the measured number.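

In this assay, placing 3-chloro-4-fluorophenyl on the carbonyl carbon of the core with the bare nitrogen gives a 2.0-fold lower number from compound 3 to compound 4 (0.30 log units; within the scatter), and this step does not differ meaningfully from the one seen on the core that carries the (5-methyl-1H-imidazol-4-yl)methyl: the same change on two cores in this assay, a 3.9-fold lower number (0.59 log units; beyond the scatter) from compound 1 to compound 2 and a 2.0-fold lower number (0.30 log units; within the scatter) from compound 3 to compound 4, 2.0-fold (0.30 log units) apart, within the scatter of two such steps Read the other way, removing the (5-methyl-1H-imidazol-4-yl)methyl gives a 4.2-fold higher number from compound 2 to compound 4 (0.63 log units; beyond the scatter), and this step likewise agrees with its earlier counterpart: the same change on two cores in this assay, a 2.1-fold higher number (0.33 log units; beyond the scatter) from compound 1 to compound 3 and a 4.2-fold higher number (0.63 log units; beyond the scatter) from compound 2 to compound 4, 2.0-fold (0.30 log units) apart, within the scatter of two such steps The two changes therefore behave consistently across these four compounds, but this does not prove that their sizes are the same, since the step to compound 4 alone stays within the scatter, and a single pair of aryl groups on two cores gives no general rule for the series.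

As far as these compounds go, it remains open whether a plain phenyl or a 4-methoxyphenyl on the carbonyl carbon would follow the same course on both cores, and whether a simple methyl on the nitrogen on the aromatic ring would behave like hydrogen or like the (5-methyl-1H-imidazol-4-yl)methyl. Also open, from the compounds shown here alone, is whether a 3-chlorophenyl or a 4-fluorophenyl alone would give the same step as 3-chloro-4-fluorophenyl.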